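This account rests on a few compounds, and the source may have more. Where it says the series, first, only, none or still open, it means among the compounds named here.

Compound 1 `COc1ccc(COC(=O)[C@H](CSCC2CCCCC2)NC(=O)[C@@H]2CSCN2C(=O)OC(C)(C)C)cc1` gives 390 nM in an assay on IMR-32 cells for inhibition of Voltage-dependent N-type calcium channel subunit alpha-1B (Homo sapiens); on this read-out lower numbers stand for stronger inhibition and higher numbers for weaker inhibition.
Compound 2 `COc1ccc(COC(=O)[C@@H](N)CSCC2CCCCC2)cc1` gives 5800 nM in this assay.

Of these two numbers compound 2 holds the higher one, with compound 1 sitting well below it, beyond the scatter. Compound 3 `COc1ccc(COC(=O)[C@H](CSCC2CCCCC2)NC(=O)CC(C)C)cc1` is compound 2 with isobutylcarbonyl in place of hydrogen on an amine nitrogen. Among the measured compounds shown here, no measured pair shows this exact change on its own. In this assay compound 3 is expected to give a lower number than compound 2, a step of a 4.8-fold lower number from compound 2 to compound 3 (0.68 log units; beyond the scatter), because compound 1 gives 390 nM while also carrying an amide in place of the free amine. For compound 3 the estimate is 1200 nM, expected to fall between 300 nM and 4000 nM.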

Compound 3, half-maximal inhibitory concentration: 1200 nM
Beside the measured number, compound 3's estimate shows no gap at the digits printed, and the stated range covers the measured number.
By their numbers in this assay, from the lowest: compound 1; then compound 3; then compound 2.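

In this assay, isobutylcarbonyl on the amine nitrogen is enough on its own to strengthen inhibition, with no ring in the added group: a 4.8-fold lower number from compound 2 to compound 3 (0.68 log units; beyond the scatter). What sits on the carbonyl carbon also matters, since isobutyl in place of 3-(tert-butoxycarbonyl)-1,3-thiazolidin-4-yl gives a 3.1-fold higher number from compound 1 to compound 3 (0.49 log units; beyond the scatter). Nothing measured here explains either step. Still open, from the compounds shown here alone, is how an acetyl group, a longer acyl chain or an acyl group carrying a carboxylic acid would compare. Also open, going by these compounds, is which part of 3-(tert-butoxycarbonyl)-1,3-thiazolidin-4-yl matters, the ring or the tert-butoxycarbonyl group.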